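This account rests on a few compounds, and the source may have more. Where it says the series, first, only, none or still open, it means among the compounds named here.

In an in vitro assay on Sf21 cells for inhibition of high affinity 3',5'-cyclic-AMP phosphodiesterase 7A (Homo sapiens) (on this read-out higher numbers stand for weaker inhibition and lower numbers for stronger inhibition), compound 1 `CNc1nc(NC2(C#N)CCCCC2)nc(OC)n1` gives 521 nM and compound 2 `CNc1nc(NC2(C#N)CCCCC2)nc(C2CC2)n1` gives 539 nM; the change between them is a 1.0-fold higher number from compound 1 to compound 2 (0.01 log units; within the scatter). Compound 3 `CNc1nc(NC2(C#N)CCCCC2)nc(N2CCCC2)n1` reaches only a limit of the assay in this assay, namely > 5000 nM. That value is one of those sitting at the limit of > 5000 nM in this assay, at which 1 of the 3 values shown sits. The two measured steps leading to compound 3 are both beyond the scatter: an at least 9.5-fold higher number from compound 1 to compound 3 (0.98 log units; beyond the scatter) and an at least 9.2-fold higher number from compound 2 to compound 3 (0.96 log units; beyond the scatter). On the numbers shown, compound 3 is therefore the weakest inhibitor of the three.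

Compound 4 `CNc1nc(NC2(C#N)CCCCC2)nc(-n2cnc(C#N)n2)n1` differs from compound 3 in one place: 3-cyano-1H-1,2,4-triazol-1-yl in place of pyrrolidin-1-yl on an aromatic carbon. The measured steps bear on this change only in one way: each time pyrrolidin-1-yl entered, inhibition became at least modestly weaker, so its departure may undo part of that loss. Among the measured compounds shown here, no measured step shows how 3-cyano-1H-1,2,4-triazol-1-yl behaves at this position, so the expectation is uncertain. For compound 4 a step of an at least 3.3-fold lower number from compound 3 to compound 4 (0.52 log units; beyond the scatter) towards stronger inhibition is expected in this assay. Compound 4 is estimated at 1500 nM, with a likely range from 300 nM to 8000 nM.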

Compound 4, half-maximal inhibitory concentration: > 5000 nM
Compound 4 gave a limit, no number (the forecaster's own chance of this, stated with the estimate: 35%); at least 3.3-fold (0.52 log units) between middle value and limit.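

In this assay, the loss seen with pyrrolidin-1-yl is not confined to that one group: 3-cyano-1H-1,2,4-triazol-1-yl shows an at least 9.5-fold higher number from compound 1 to compound 4 (0.98 log units; beyond the scatter) when it takes the place of methoxy, and an at least 9.2-fold higher number from compound 2 to compound 4 (0.96 log units; beyond the scatter) when it takes the place of cyclopropyl. An aromatic ring carrying a nitrile, joined through a ring nitrogen, therefore does not recover the inhibition lost with the non-aromatic pyrrolidin-1-yl. Compound 4 gives only a limit, not a number, and the step from compound 3 cannot be read, as both values are limits: the limit of > 5000 nM in this assay, at which 2 of the 4 values shown sit.

Going by these compounds, how far compound 3 and compound 4 differ therefore stays unknown. Also open, on these data alone, is whether a small dimethylamino group, or a phenyl ring joined through carbon, would keep inhibition at this position.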